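From 4-methylphenyl to 2-chlorophenyl on the shared core

The source may report more compounds than this note shows. Statements on the series, on what has been measured and on what is new or still open speak of the compounds shown alone.

In a functional assay on MCF7 cells (Homo sapiens) for cytotoxicity, read by ELISA, with a stated time of 4 days (a lower number here means a stronger inhibitor, a higher number a weaker inhibitor), compound 1 `Clc1ccc(-c2cc(-c3ccoc3)cc(-c3ccco3)n2)s1` gives 4740 nM, compound 2 `Cc1ccccc1-c1cc(-c2ccoc2)cc(-c2ccc(Cl)s2)n1` gives 1430 nM and compound 3 `Cc1ccc(-c2cc(-c3ccoc3)cc(-c3ccc(Cl)s3)n2)cc1` gives 5340 nM. Compound 3 shares the high end of this small set with compound 1, as a 1.1-fold higher number from compound 1 to compound 3 (0.05 log units; within the scatter) does not separate the two, while compound 2 stands lower.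

Compound 4 `Clc1ccc(-c2cc(-c3ccoc3)cc(-c3ccccc3Cl)n2)s1` carries 2-chlorophenyl in place of 4-methylphenyl on an aromatic carbon, next to the ring nitrogen: 2-chlorophenyl in place of 4-methylphenyl on an aromatic carbon. Among the measured compounds shown here, its closest measured relative is compound 2, which has 2-methylphenyl at that place, but no pair with chlorine and methyl exchanged has been measured. For the measured compounds named here, two steps bear on the change: a 3.7-fold higher number from compound 2 to compound 3 (0.57 log units; beyond the scatter), which would be run in reverse here, and a 3.3-fold lower number from compound 1 to compound 2 (0.52 log units; beyond the scatter), which points the same way. A modest step towards a lower number in this assay is therefore expected, with real uncertainty about its size. The expected step is a 2.8-fold lower number from compound 3 to compound 4 (0.45 log units; beyond the scatter). For compound 4 the estimated value is 1900 nM, with an expected range of 750 nM to 4800 nM.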

Compound 4, half-maximal inhibitory concentration: 7360 nM
Beside the measured number, compound 4's estimate is 3.9-fold (0.59 log units) below it; the whole stated range lies below it.
By their numbers in this assay, from the lowest: compound 2; then compounds 1, 3 and 4 (each within the scatter of the next).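

In this assay, among the compounds shown here, the lower number of compound 2 does not carry over to chlorine at the same place on the phenyl ring: a 5.1-fold higher number from compound 2 to compound 4 (0.71 log units; beyond the scatter) is the first measured exchange of chloro for methyl there. Among the groups measured at this position, only 2-methylphenyl stands apart, as a 1.4-fold higher number from compound 3 to compound 4 (0.14 log units; within the scatter) and a 1.6-fold higher number from compound 1 to compound 4 (0.19 log units; within the scatter) leave compounds 1, 3 and 4 undivided. Nothing measured on these compounds accounts for the gap between chloro and methyl at this place.

Open, as far as these compounds go, is whether an ethyl or methoxy group in place of the methyl of compound 2 keeps the lower number, or whether the methyl group alone gives it. Also open, from the compounds shown here alone, is whether that number holds with an amine in place of the furan-3-yl group.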